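Dichlorophenyl sulfone variant of a fluorophenyl quinoline sulfone

The source may hold more compounds than are shown below. What is called first, only, known or untested is meant among the compounds shown, and "the series" means these compounds.

Measured compounds:
Compound 1 `COc1cccc(-c2c(S(=O)(=O)c3cc(Cl)cc(Cl)c3)cnc3c(F)cccc23)c1` gives 2.31 mL/min in an ADME assay on microsomes from liver (Homo sapiens) for metabolic stability, tested at 2.5 uM; a lower number here means slower removal, a higher number faster removal of the compound.
Compound 2 `O=S(=O)(c1cccc(F)c1)c1cnc2c(F)cccc2c1-c1cccc(F)c1` gives 1.14 mL/min in this assay.

In this assay, compound 2 stands lowest of the two numbers; its nearest neighbour is compound 1, whose number is higher by an amount beyond the usual scatter. The two measured compounds differ from each other in two places at once, so no single-change comparison between them exists.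

Compound 3 `O=S(=O)(c1cc(Cl)cc(Cl)c1)c1cnc2c(F)cccc2c1-c1cccc(F)c1` has not yet been measured in this assay. It differs from compound 2 in one place: 3,5-dichlorophenyl in place of 3-fluorophenyl on a sulfonyl sulfur. Compound 1 also carries a 3,5-dichlorophenyl on its sulfonyl sulfur and gives 2.31 mL/min, but since compound 1 differs from compound 2 elsewhere as well, that number is only a loose pointer.

On this basis a step toward a higher number is expected for a 1.6-fold higher number from compound 2 to compound 3 (0.20 log units; within the scatter), of modest size and possibly within the scatter. For compound 3 the estimated value in this assay is 1.8 mL/min, with a range from 0.9 mL/min to 3.6 mL/min.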

Compound 3, intrinsic clearance in a liver preparation (reported as CLH), per the amount of preparation that the assay uses: 1.08 mL/min
For compound 3 the middle estimate is 1.7-fold (0.22 log units) above the measured one, and the stated range covers the measured number.
By their numbers in this assay, from the lowest: compounds 3 and 2 (each within the scatter of the next); then compound 1.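

In this assay, 3,5-dichlorophenyl in place of 3-fluorophenyl on a sulfonyl sulfur gives a 1.1-fold lower number from compound 2 to compound 3 (0.02 log units; within the scatter) and so leaves the read-out unmoved, which shows that these two groups cannot be told apart at this position. Compound 3 also isolates the other place, since it keeps the 3,5-dichlorophenyl of compound 1 and has fluoro in place of methoxy on an aromatic carbon, a single change that gives a 2.1-fold lower number from compound 1 to compound 3 (0.33 log units; beyond the scatter) and so lies beyond the scatter, unlike the change on the sulfonyl sulfur. Among these compounds the 3,5-dichlorophenyl group therefore does not by itself go with the higher number of compound 1, though nothing shown here accounts for either result.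

As far as these compounds go, the two aromatic groups compared on the sulfonyl sulfur are both halogenated phenyl rings, so it remains open whether the read-out would stay level with a phenyl ring carrying an amine or a carboxylic acid, or with a longer chain in that place. On the aromatic carbon only methoxy and fluoro can be compared, and a nitrile or a trifluoromethyl group there remains an open case.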